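A few compounds are considered here, and "the series" means these few. Any claim that something is new, unique, unknown or untested is made for them only; others in the source may bear on it.

Compound 1 `CC1(C)O[C@@H](CO)[C@H](Cn2cc(Cn3c4c(c5ccccc53)C(=O)c3c[n+]([O-])c5ccccc5c3C4=O)nn2)O1` gives 500 nM in a toxicity assay on L02 cells (Homo sapiens) for cytotoxicity, read by MTT assay, with a stated time of 72 h; on this read-out lower numbers stand for stronger inhibition and higher numbers for weaker inhibition.
Compound 2 `O=C1c2c[n+]([O-])c3ccccc3c2C(=O)c2c1c1ccccc1n2CCCCN1CCCCC1` gives 610 nM in this assay.
Compound 3 `O=C1c2c[n+]([O-])c3ccccc3c2C(=O)c2c1c1ccccc1n2Cc1cn([C@@H]2O[C@H](CO)[C@@H](O)[C@H](O)[C@H]2O)nn1` gives 420 nM in this assay.

The three measured compounds share one core and differ only in the group on the aromatic nitrogen. Their values in this assay lie close together: the gap from compound 2 to compound 1 and the gap from compound 2 to compound 3 both fall within the scatter, so nothing separates compound 2 from the other two on these numbers.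

Compound 4 `CN1CCN(CCCCn2c3c(c4ccccc42)C(=O)c2c[n+]([O-])c4ccccc4c2C3=O)CC1` has not been measured. It differs from compound 2 in one place: 4-methylpiperazin-1-yl in place of piperidin-1-yl on a saturated chain carbon, four bonds along the chain from an aromatic nitrogen. Within the data shown here, the only measured step is a 1.2-fold lower number from compound 1 to compound 3 (0.08 log units; within the scatter), and it concerns a different kind of change, a sugar-like group in place of a dioxolane-bearing chain on the aromatic nitrogen. Among the measured compounds shown here, no measured pair swaps one saturated ring for another at the end of the chain, so there is no direct precedent for the change from compound 2 to compound 4. Given that the one measured step stayed within the scatter and the group that enters resembles the group that leaves, no step beyond the scatter is expected in this assay.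

Compound 4 is therefore expected to give about 600 nM in this assay, within a range of 300 nM to 1200 nM. The expected step is a 1.0-fold lower number from compound 2 to compound 4 (0.01 log units; within the scatter).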

Compound 4, half-maximal inhibitory concentration: 80 nM
Estimate against measurement, compound 4: 7.5-fold (0.88 log units) above; measured number outside the range, below it.
By their numbers in this assay, from the lowest: compound 4; then compounds 3, 1 and 2 (each within the scatter of the next).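

In this assay, the far end of the chain proves to be a place where the group can matter: 4-methylpiperazin-1-yl in place of piperidin-1-yl gives a 7.6-fold lower number from compound 2 to compound 4 (0.88 log units; beyond the scatter), a step beyond the scatter. Among these compounds, the earlier compounds showed no such thing, since their only measured step, a 1.2-fold lower number from compound 1 to compound 3 (0.08 log units; within the scatter), stayed within the scatter and concerned a different change on the aromatic nitrogen. Here the two groups are closely related, both being six-membered non-aromatic rings with no net charge, so a change confined to that ring is enough to shift the number, although nothing shown gives a reason for the shift.

The compounds shown do not separate the second ring nitrogen from the methyl group on it, a question that piperazin-1-yl without the methyl, or morpholin-4-yl with an oxygen in that place, would address. They also leave open whether the step would persist if 4-methylpiperazin-1-yl sat on a shorter or a longer chain, such as 3-(4-methylpiperazin-1-yl)propyl.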